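Phenyl on the hydrazide nitrogen of a thiophene carboxamide

The source may report more compounds than this note shows. Statements on the series, on what has been measured and on what is new or still open speak of the compounds shown alone.

Measured so far in an in vitro assay on CHOk1 cells with adenosine receptor A1 (Homo sapiens) as the target; a higher number here means that more compound is needed for the effect, a lower number that less compound is needed:
compound 1 `Nc1sc2c(c1C(=O)NCc1ccccc1)CCN(Cc1ccccc1)C2` gives 13100 nM;
compound 2 `NNC(=O)c1c(N)sc2c1CCN(Cc1ccccc1)C2` gives 8900 nM.

Compound 2 has the lowest of the two numbers, but its step to compound 1, a 1.5-fold lower number from compound 1 to compound 2 (0.17 log units; within the scatter), is within the scatter, so the two values are taken as equal. Compound 3 `Nc1sc2c(c1C(=O)NNc1ccccc1)CCN(Cc1ccccc1)C2` is not yet measured; it differs from compound 2 by phenyl in place of hydrogen on an amine nitrogen. Going by the values given here, no measured step changes this nitrogen, and the one step on the amide side, a 1.5-fold lower number from compound 1 to compound 2 (0.17 log units; within the scatter), did nothing beyond the scatter. The step from compound 2 to compound 3 is therefore expected to be small, a 1.1-fold higher number from compound 2 to compound 3 (0.05 log units; within the scatter). Compound 3 is estimated at 10000 nM, within 3000 nM to 35000 nM.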

Compound 3, half-maximal effective concentration: 7800 nM
Beside the measured number, compound 3's estimate is 1.3-fold (0.11 log units) above it, within the range that was stated.
By their numbers in this assay, from the lowest: compounds 3, 2 and 1 (each within the scatter of the next).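

In this assay, phenyl on the amine nitrogen is tolerated, with a 1.1-fold lower number from compound 2 to compound 3 (0.06 log units; within the scatter) as the step, so this nitrogen can carry an aromatic ring of six carbons without leaving the scatter. Anilino in place of benzyl on the amide-type nitrogen reads the same way, with a 1.7-fold lower number from compound 1 to compound 3 (0.23 log units; within the scatter) as the step, and the three compounds cannot be told apart. No available evidence accounts for this flat result. As far as these compounds go, whether a carboxylic acid or a dimethylamino group on that phenyl would shift the number beyond the scatter remains open.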